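The source may report more compounds than this note shows. Statements on the series, on what has been measured and on what is new or still open speak of the compounds shown alone.

Measured so far in a functional assay on M21 cells (Homo sapiens) for antiproliferative activity, read by sulforhodamine B assay, with a stated time of 48 h; on this read-out higher numbers stand for weaker inhibition and lower numbers for stronger inhibition:
- compound 1 `O=C1NCCN1c1ccc(S(=O)(=O)Nc2ccc3[nH]ccc3c2)cc1`: 87 nM
- compound 2 `Cc1ccc(NS(=O)(=O)c2ccc(N3CCNC3=O)cc2)cc1C`: 94 nM
- compound 3 `O=C1NCCN1c1ccc(S(=O)(=O)Nc2ccc(F)c(F)c2)cc1`: 220 nM

Compound 3 carries the highest number of the three in this assay, at 220 nM. Both other compounds lie lower, and the gap to each is beyond the scatter.

The next compound to be read is compound 4 `Cc1ccc(C)c(NS(=O)(=O)c2ccc(N3CCNC3=O)cc2)c1`. The change is 2,5-dimethylphenyl in place of 3,4-difluorophenyl on a sulfonamide nitrogen.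

Among the compounds with values here, one measured step bears on this directly: a 2.3-fold higher number from compound 2 to compound 3 (0.37 log units; beyond the scatter). It is modest, and it swaps 3,4-dimethylphenyl for 3,4-difluorophenyl. Read in reverse, it gives some ground for expecting a dimethylphenyl compound to return a lower number than compound 3. Within the data shown here, the guide is imperfect, since compound 4 carries its methyl groups as 2,5-dimethylphenyl rather than 3,4-dimethylphenyl, and no measured pair isolates that difference. The expected direction is therefore toward a lower number, with less confidence in the size.

The estimated step is a 1.6-fold lower number from compound 3 to compound 4 (0.20 log units; within the scatter), smaller than the measured one and possibly not clear of the scatter. Compound 4 is expected at about 140 nM, with an estimated range of 50 nM to 450 nM.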

Compound 4, half-maximal inhibitory concentration: 27 nM
Compound 4: middle estimate off by 5.2-fold (0.71 log units), on the high side; the measured number lies below the stated range.
By their numbers in this assay, from the lowest: compound 4; then compounds 1 and 2 (each within the scatter of the next); then compound 3.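

In this assay, within the data shown here, the step of a 3.5-fold lower number from compound 2 to compound 4 (0.54 log units; beyond the scatter) is the first to hold the substituent type fixed and change only its placement on the aryl group on the sulfonamide nitrogen, and it shows that 2,5-dimethylphenyl and 3,4-dimethylphenyl are not interchangeable at this position. The step of an 8.1-fold lower number from compound 3 to compound 4 (0.91 log units; beyond the scatter) changes both the substituent type and its placement, so its size cannot be assigned to either change alone, though the pair with compound 2 shows that placement by itself gives a step beyond the scatter. No measurement at hand accounts for the difference between these aryl groups.

The compounds shown leave open whether 2,5-difluorophenyl would differ from 3,4-difluorophenyl in the same direction, which would separate the effect of placement from that of the substituent type. They also leave open whether both methyl groups of 2,5-dimethylphenyl are needed, which a 2-methylphenyl or 3-methylphenyl group could test, and whether a methoxy group, a chlorine or an amine would be tolerated in their place.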